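A few compounds are considered here, and "the series" means these few. Any claim that something is new, unique, unknown or untested is made for them only; others in the source may bear on it.

In a functional assay on CNE cells (Homo sapiens) for cytotoxicity, read by MTT assay, with a stated time of 72 h (on this read-out higher numbers stand for weaker inhibition and lower numbers for stronger inhibition), compound 1 `COc1ccc(NC(=O)COC(=O)/C=C/c2cc(OC)c(OCc3ccc(Cl)c(Cl)c3)c(OC)c2)cc1` gives > 200000 nM, which is a limit of the assay rather than a number. Compound 2 `COc1ccc(NC(=O)COC(=O)/C=C/c2cc(OC)c(OCc3ccccc3)c(OC)c2)cc1` likewise gives > 200000 nM, again only a limit. The step that the two limits leave unreadable from compound 1 to compound 2 is thus not readable in size; both values sit at the limit of > 200000 nM in this assay, at which 2 of the 2 values shown sit. Compound 3 `COc1cc(/C=C/C(=O)OCC(=O)Nc2ccc(Cl)cc2)cc(OC)c1OCc1ccc(Cl)c(Cl)c1` differs from compound 1 by chloro in place of methoxy on an aromatic carbon. Going by the values given here, no measured step bears on this change, and the single measured step yields no size at all. Compound 3 is expected to remain near the limit, at 250000 nM with a range of 100000 nM to 600000 nM. The step that the limit leaves unreadable from compound 1 to compound 3 is expected to be none beyond the scatter.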

Compound 3, half-maximal inhibitory concentration: > 200000 nM
Compound 3: no number, only a limit; the forecaster's own chance of this, stated with the estimate: 80%; the middle value does not contradict the limit.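

Going by these compounds alone, compound 1 and compound 3 both sit only at a limit, so no step between them can be read: the limit of > 200000 nM in this assay, at which 3 of the 3 values shown sit. How far any of these compounds lies past that limit in this assay stays open.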